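The source may report more compounds than this note shows. Statements on the series, on what has been measured and on what is new or still open speak of the compounds shown alone.

Compound 1 `N=C(S)CCCn1nc(-c2ccccc2)ccc1=O` in a functional assay on the whole organism (stomach) for inhibition, with Rattus norvegicus as the target, at a dose of 100 mg/kg by the intraduodenal route (a higher number here means more inhibition at the dose given (going by the name of the read-out), a lower number less inhibition), gives 75.6%.
Compound 2 `CCOC(=O)CCn1nc(-c2ccccc2)ccc1=O` in this assay gives 6.3%.
Compound 3 `Cc1ccc(=O)n(CC(C)C(=N)S)n1` in this assay gives 30.2%.

Compound 3 stands second highest of the three, beyond the scatter from compound 2 beneath it and from compound 1 above it. Compound 4 `CC(Cn1nc(-c2ccccc2)ccc1=O)C(=N)S` differs from compound 3 in one place: phenyl in place of methyl on an aromatic carbon. For the measured compounds named here, the only measured step, a number 69.3 percentage points lower from compound 1 to compound 2 (beyond the scatter), concerns the group on the saturated chain carbon, not the aromatic carbon, and so does not bear directly on this change. Compound 1 carries the phenyl and is the highest of the three, but it also differs from compound 3 in its chain, so the comparison is indirect. An upward step of a number 24.8 percentage points higher from compound 3 to compound 4 (beyond the scatter) is therefore expected, with wide uncertainty. Compound 4 is expected to give 55% in this assay, in a range from 25% to 80%.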

Compound 4, a percentage reported as inhibition, in the whole organism at one dose (the size of the read-out at that dose, not a potency): 86.4%
Compound 4: the middle estimate sits 31.4 percentage points below what was measured, outside the stated range (above it).
By their numbers in this assay, from the lowest: compound 2; then compound 3; then compound 1; then compound 4.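

In this assay, phenyl in place of methyl on the aromatic carbon gives a number 56.2 percentage points higher from compound 3 to compound 4 (beyond the scatter), so the group at this position alone moves the read-out by a large amount. With the phenyl present, the side group on the saturated chain carbon still counts: one swap gives a number 80.1 percentage points higher from compound 2 to compound 4 (beyond the scatter), while rearranging the same heavy atoms gives only a number 10.8 percentage points higher from compound 1 to compound 4 (beyond the scatter). Nothing measured here explains either change.

Going by these compounds, whether a pyridyl ring or a benzyl group would hold this gain on the aromatic carbon remains open. So does whether an amine or a carboxylic acid could replace the side group.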